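The source may hold more compounds than are shown below. What is called first, only, known or untested is meant among the compounds shown, and "the series" means these compounds.

Compound 1 `CC(=O)Nc1ccc(OCc2nnc(SCC(=O)Nc3ccc(Br)cc3)n2Cc2ccccc2)cc1` stands in a toxicity assay on MT4 cells (Homo sapiens) for cytotoxicity, read by MTT assay, with a stated time of 5 days (a higher number here means that more compound is tolerated, a lower number that less compound is tolerated), only at a limit: in this assay compound 1 gives >= 3.99 ug/mL. Its near relative compound 2 `CCOC(=O)c1ccc(NC(=O)CSc2nnc(COc3ccc(NC(C)=O)cc3)n2Cc2ccccc2)cc1` gives 91.1 ug/mL in this assay. The step that the limit leaves unreadable from compound 1 to compound 2 has no readable size because of the limit of >= 3.99 ug/mL in this assay, at which 1 of the 2 values shown sits. Compound 3 `O=C(CSc1nnc(COc2ccc3ccccc3c2)n1Cc1ccccc1)Nc1ccc(Br)cc1` differs from compound 1 in one place: naphthalen-2-yl in place of 4-acetamidophenyl on an oxygen on a saturated carbon. Among the measured compounds shown here, no measured step touches this change, and the single measured step gives no size to lean on. Compound 3 is therefore estimated at 30 ug/mL in this assay, with a range from 5 ug/mL to 150 ug/mL. This estimate means an expected step that the limit leaves unreadable from compound 1 to compound 3.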

Compound 3, half-maximal cytotoxic concentration: 58.1 ug/mL
For compound 3 the middle estimate is 1.9-fold (0.29 log units) below the measured one, and the stated range covers the measured number.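

No size can be read for the step from compound 1 to compound 3, because compound 1 stands only at a limit: the limit of >= 3.99 ug/mL in this assay, at which 1 of the 3 values shown sits.

The compounds shown leave open how far naphthalen-2-yl in place of 4-acetamidophenyl, or ethoxycarbonyl in place of bromo, shifts the tolerated concentration in this assay.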